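Swapping the aryl on the ring nitrogen of compound 3

The source may hold more compounds than are shown below. What is called first, only, known or untested is meant among the compounds shown, and "the series" means these compounds.

Compound 1 `CC(C)c1ccc(N2N=C(C(C)(C)C)CC2c2ccc(O)cc2)cc1`: 54.9%
Compound 2 `CC(C)(C)C1=NN(c2ccc(C(=O)O)cc2)C(c2ccc(O)cc2)C1`: 47.9%
Compound 3 `CC(C)(C)C1=NN(c2cccc(Cl)c2)C(c2ccc(O)cc2)C1`: 96.8%

In an assay on isolated protein for inhibition of protein kinase C zeta type (Homo sapiens), with a stated time of 4 min, tested at 62.5 uM (on this read-out lower numbers stand for less inhibition and higher numbers for more inhibition at the one concentration tested (going by the name of the read-out)), compound 3 stands highest of the three measured compounds, with compound 1 the nearest and compound 2 the furthest; both lie beyond the scatter below it. Compound 4 `CC(C)(C)C1=NN(c2ccc(F)cc2F)C(c2ccc(O)cc2)C1` differs from compound 3 in one place: 2,4-difluorophenyl in place of 3-chlorophenyl on an amine nitrogen in a ring. For the measured compounds named here, the only measured step that touches the same part of the shared core is the one from compound 1 to compound 2, where a carboxy replaces an isopropyl on the aromatic carbon of that aryl group, and it gave a number 7 percentage points lower from compound 1 to compound 2 (within the scatter). That step tells little about a change that leaves a 3-chlorophenyl and brings in a 2,4-difluorophenyl, and the gap between compound 3 and the other two shows that this aryl group matters. The account therefore expects a downward step in this assay of moderate size, a number 21.8 percentage points lower from compound 3 to compound 4 (beyond the scatter), with wide uncertainty. Compound 4 is estimated at 75%, in the range 45% to 98%.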

Compound 4, a percentage reported as inhibition, at one concentration (the size of the read-out at that concentration, not a potency): 68%
For compound 4 the middle estimate is 7 percentage points above the measured one, and the stated range covers the measured number.
By their numbers in this assay, from the lowest: compounds 2 and 1 (each within the scatter of the next); then compound 4; then compound 3.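

In this assay, 2,4-difluorophenyl in place of 3-chlorophenyl on the amine nitrogen in a ring gives a number 28.8 percentage points lower from compound 3 to compound 4 (beyond the scatter), so among these compounds, a halogen-bearing aryl group does not by itself keep the number at the level of compound 3. Even so, compound 4 at 68% stands above both compound 1 at 54.9% and compound 2 at 47.9% on the printed values, which places this change between the chlorinated aryl group and the isopropyl and carboxy ones. No measurement here accounts for the fall.

The compounds shown leave open whether the difference follows the change of halogen or the change in where the halogens sit on the aryl group. They also do not show how an unsubstituted phenyl, or a methoxy or amine group on that aryl ring, would compare.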